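The source may report more compounds than this note shows. Statements on the series, on what has been measured and on what is new or still open speak of the compounds shown alone.

Working notes on the series. Among the compounds with values here, compound 1 `CCOC(=O)c1ccc2[nH]c(-c3ccc(Cl)cc3)c(Oc3ccc(Cl)cc3)c2c1` and compound 2 `CCN(CC)C(=S)Sc1c(-c2ccccc2)[nH]c2ccc(Br)cc12` are the two measured members so far. In a functional assay on SK-MEL-28 cells (Homo sapiens) for inhibition, read by MTT assay, with a stated time of 72 h (on this read-out lower numbers stand for stronger inhibition of growth and higher numbers for weaker inhibition of growth), compound 1 gives 28000 nM. In this assay compound 2 gives 28000 nM. Compound 1 stands level with compound 2 at the digits recorded, and the two values lie within the scatter of each other, so nothing can be said of any order between them. Within the data shown here, no pair of measured compounds differs in a single place, so no measured step is available to size the effect of one change on growth inhibition of these cells.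

Compound 3 `COc1ccc2[nH]c(-c3ccc(Cl)cc3)c(Oc3ccc(Cl)cc3)c2c1` is the next member. Against compound 1 it shows (methoxy in place of ethoxycarbonyl on an aromatic carbon). Among the measured compounds shown here, no measured step bears on this change. For the measured compounds named here, the only guidance is that both measured compounds sit at the same value, so the expected step from compound 1 to compound 3 in this assay is taken as no change at the digits printed from compound 1 to compound 3 (within the scatter), none beyond the scatter in either direction. Compound 3 is accordingly expected to give 28000 nM in this assay, with a range from 8000 nM to 90000 nM that reflects the absence of any measured step for this change.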

Compound 3, concentration for 50% growth inhibition: 57000 nM
The estimate for compound 3 lay 2.0-fold (0.31 log units) below the measured number; low and high end bracket the measured number.
By their numbers in this assay, from the lowest: compounds 1 and 2 (each within the scatter of the next); then compound 3.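

In this assay, within the data shown here, methoxy in place of ethoxycarbonyl on this aromatic carbon gives a 2.0-fold higher number from compound 1 to compound 3 (0.31 log units; beyond the scatter), the first measured single change, and it shows that growth inhibition of these cells is not indifferent to what stands at this position. On this read-out the higher number means weaker inhibition, so the ethoxycarbonyl of compound 1 reads better here than the methoxy of compound 3, though the step remains modest. The change swaps a group of 5 heavy atoms with a double bond outside the aromatic rings for one of 2 heavy atoms without it, and no accompanying measurement bears on what lies behind the step.

Among these compounds, with only this one step, the size of the group and the loss of the carbonyl cannot be told apart, and nothing yet shows whether the same change would read alike on the other members. On these data alone, a carboxylic acid, a primary amide or a longer alkoxy chain such as n-butoxy on this same aromatic carbon remains open, as does the unsubstituted hydrogen there.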